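This account rests on a few compounds, and the source may have more. Where it says the series, first, only, none or still open, it means among the compounds named here.

Values in a functional assay on MCF7 cells (Homo sapiens) for antiproliferative activity, with a stated time of 48 h; on this read-out higher numbers stand for lower toxicity in this test and lower numbers for higher toxicity in this test:
- compound 1 `Cc1cc(O)c(C2=NN(c3ccc(S(N)(=O)=O)cc3)C(c3ccccc3O)C2)cc1Cl`: 49500 nM
- compound 2 `Cc1cc(O)c(C2=NN(c3ccc(S(N)(=O)=O)cc3)C(c3ccccc3Cl)C2)cc1Cl`: 6350 nM
- compound 3 `Cc1cc(O)c(C2=NN(c3ccc(S(N)(=O)=O)cc3)C(/C=C/c3ccccc3)C2)cc1Cl`: 40100 nM

Compound 3 gives the second highest of the three numbers in this assay. Its nearest neighbour is compound 1, with a 1.2-fold lower number from compound 1 to compound 3 (0.09 log units; within the scatter); its furthest is compound 2, with a 6.3-fold higher number from compound 2 to compound 3 (0.80 log units; beyond the scatter). Compound 4 `COc1ccc(C2CC(c3cc(Cl)c(C)cc3O)=NN2c2ccc(S(N)(=O)=O)cc2)cc1OC` is not yet measured. The change from compound 3 to compound 4 is 3,4-dimethoxyphenyl in place of 2-phenylethenyl on a saturated ring carbon.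

Among the measured compounds shown here, two measured steps concern this same saturated ring carbon: the step of a 1.2-fold lower number from compound 1 to compound 3 (0.09 log units; within the scatter), which stays within the scatter, and the step of a 6.3-fold higher number from compound 2 to compound 3 (0.80 log units; beyond the scatter), which is modest. The step of a 7.8-fold lower number from compound 1 to compound 2 (0.89 log units; beyond the scatter) shows that the aromatic substituent carried by this ring carbon can move the number modestly. No measured group with two methoxy groups exists in the series, so the direction is open; a change of modest size in either direction is plausible, with no step beyond the scatter being the central expectation.

Compound 4 is therefore expected to give 30000 nM in this assay, within a range of 8000 nM to 90000 nM, which corresponds to an expected step of a 1.3-fold lower number from compound 3 to compound 4 (0.13 log units; within the scatter).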

Compound 4, concentration lethal to 50% of the cells: > 100000 nM
Compound 4: a limit, no number; the forecaster's own chance of this, stated with the estimate: 10%; middle value at least 3.3-fold (0.52 log units) away from the limit.
By their numbers in this assay, from the lowest: compound 2; then compounds 3 and 1 (each within the scatter of the next). At a limit, above all of these: compound 4.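

In this assay compound 4, with 3,4-dimethoxyphenyl on the saturated ring carbon, gives a limit and not a number: the limit of > 100000 nM in this assay, at which 1 of the 4 values shown sits.

Among the compounds shown here, the earlier groups at this carbon left compound 2 apart from a level shared by compounds 1 and 3, whereas 3,4-dimethoxyphenyl moves the read-out past that level, with an at least 2.4-fold higher number from compound 3 to compound 4 (0.39 log units; beyond the scatter) and an at least 15-fold higher number from compound 2 to compound 4 (1.19 log units; beyond the scatter), the first step at this position printed as large. The step of an at least 2.0-fold higher number from compound 1 to compound 4 (0.30 log units; that floor lies within the scatter) cannot be read as a separation, so compound 1 and compound 4 stay unordered.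

On these data alone, how far the number of compound 4 lies beyond the limit remains open. Also open, as far as these compounds go, is whether the step belongs to the two methoxy groups together or to the aryl group as such, a question that an unsubstituted phenyl or a single methoxy group at this carbon would address.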